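The compounds below may be only part of what the source reports. "The series", "measured", "known", "first", "only" and "open" are said of these compounds alone.

Series notes on tolerability in TZM cells. Compound 1 `Cc1cc(N)cc(C)c1Oc1cc(Nc2ccc(C#N)cc2)c(N)cc1C(F)(F)F`, compound 2 `COC(=O)c1cc(N)c(Nc2ccc(C#N)cc2)cc1Oc1c(C)cc(/C=C/C#N)cc1C` and compound 3 `Cc1cc(CCC#N)cc(C)c1Oc1cc(Nc2ccc(C#N)cc2)c(N)cc1S(N)(=O)=O` have been run in an ADME assay on TZM cells (Homo sapiens) for cytotoxicity, read by XTT assay, with a stated time of 4 days; a higher number here means that more compound is tolerated, a lower number that less compound is tolerated. Compound 1 gives 15800 nM in this assay. Compound 3 gives 11100 nM in this assay; this is the lower of the two numbers recorded, with compound 1 the nearest, and the two values lie within the scatter of each other. For compound 2, this assay reports only a limit, > 22800 nM, which is the limit of > 22800 nM in this assay, at which 1 of the 3 values shown sits.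

Compound 4 `Cc1cc(CCC#N)cc(C)c1Oc1cc(Nc2ccc(C#N)cc2)c(N)cc1C(F)(F)F` has not yet been measured in this assay. It differs from compound 3 in one place: trifluoromethyl in place of sulfamoyl on an aromatic carbon. Among the compounds with values here, no step between two measured compounds covers this change. Compound 1 carries trifluoromethyl and compound 3 carries sulfamoyl, but they differ elsewhere too, so their two values only show that both tolerated concentrations sit within the scatter of each other. In this assay a small step is expected, a 1.3-fold higher number from compound 3 to compound 4 (0.10 log units; within the scatter), in neither direction beyond the scatter. Compound 4 is therefore estimated at 14000 nM in this assay, within 5500 nM to 36000 nM.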

Compound 4, half-maximal cytotoxic concentration: > 7100 nM
Compound 4: no number, only a limit (the forecaster's own chance of this, stated with the estimate: 25%); the middle value lies beyond the limit too.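

Within the data shown here, compound 4 gives only a limit in this assay, > 7100 nM, not a number, and no step from compound 3 or compound 1 to compound 4 can be read. The compounds shown leave open whether trifluoromethyl in place of sulfamoyl, or 2-cyanoethyl in place of amino, changes tolerance beyond the scatter.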